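Methylating the tetrazole on the shared core

The source may report more compounds than this note shows. Statements on the series, on what has been measured and on what is new or still open speak of the compounds shown alone.

Compound 1 `CC(O)c1cc(-c2ccccc2)c2ccc(OCc3cccc(C4(O)CCOCC4)c3)cc2c1` gives 520 nM in an assay on isolated protein with Polyunsaturated fatty acid 5-lipoxygenase (Homo sapiens) as the target; a higher number here means a weaker inhibitor, a lower number a stronger inhibitor. Compound 2 `OC1(c2cccc(COc3ccc4c(-c5ccccc5)cc(-c5nn[nH]n5)cc4c3)c2)CCOCC1` reaches only a limit in this assay, > 6000 nM (the limit of > 6000 nM in this assay, at which 1 of the 2 values shown sits). Among the measured compounds shown here, the one measured step, an at least 11-fold higher number from compound 1 to compound 2 (1.06 log units; beyond the scatter), concerns a different exchange than the one now followed. Compound 3 `Cn1nnnc1-c1cc(-c2ccccc2)c2ccc(OCc3cccc(C4(O)CCOCC4)c3)cc2c1` differs from compound 2 by 1-methyl-1H-tetrazol-5-yl in place of 2H-tetrazol-5-yl on an aromatic carbon. For the measured compounds named here, no measured step covers this change, so the direction is open, and compound 3 is expected near the limit of compound 2, with the step of a number no higher from compound 2 to compound 3 (the limit leaves the size open) estimated as small. Compound 3 is estimated at 6000 nM, between 1500 nM and 25000 nM.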

Compound 3, half-maximal inhibitory concentration: 3000 nM
Beside the measured number, compound 3's estimate is 2.0-fold (0.30 log units) above it, within the range that was stated.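

Compound 2 stands only at a limit: the limit of > 6000 nM in this assay, at which 1 of the 3 values shown sits. In this assay, the methylated tetrazole gives an at least 2.0-fold lower number from compound 2 to compound 3 (0.30 log units; that floor lies within the scatter), so this floor alone does not separate the two compounds. Compound 3 does give this position its first tetrazole with a measured number, and with 1-methyl-1H-tetrazol-5-yl in place of 1-hydroxyethyl the result is a 5.8-fold higher number from compound 1 to compound 3 (0.76 log units; beyond the scatter). As far as these compounds go, how far compound 2 actually lies from compound 3 stays open. So does how a carboxylic acid or an acetyl group at this position would compare with compound 1.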